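A few compounds are considered here, and "the series" means these few. Any claim that something is new, unique, unknown or untested is made for them only; others in the source may bear on it.

Compound 1 `ClCc1cccc(Cn2cnc3ncnc(Cl)c32)c1` was tested in a functional assay on K562 cells (Homo sapiens) for cytotoxicity, read by sulforhodamine B assay, with a stated time of 48 h (a higher number here means a weaker inhibitor of growth, a lower number a stronger inhibitor of growth), where compound 1 gives 47900 nM. Within the data shown here, that is the higher of the two numbers recorded so far: the only other measured compound, compound 2 `ClCc1cccc(Cn2cnc3c(Cl)ncnc32)c1`, gives 15100 nM in this assay, and the gap between the two lies beyond the usual scatter, so compound 1 stands as the weaker inhibitor of growth of the pair. The next compound, compound 3 `ClCc1cccc(Cn2cnc3nc(Cl)nc(Cl)c32)c1`, has not yet been measured in this assay. It differs from compound 1 in one place: chloro in place of hydrogen on an aromatic carbon. Among the measured compounds shown here, no step of this kind has been measured among the compounds already known, so the expected change rests on the structures alone. The step is expected to be modest and toward a lower number, although a change within the scatter cannot be ruled out. Compound 3 is therefore estimated to give 25000 nM in this assay, with a range from 8000 nM to 80000 nM, which means an expected step from compound 1 to compound 3 of a 1.9-fold lower number from compound 1 to compound 3 (0.28 log units; within the scatter).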

Compound 3, concentration for total growth inhibition: 2690 nM
Estimate against measurement, compound 3: 9.3-fold (0.97 log units) above; measured number outside the range, below it.
By their numbers in this assay, from the lowest: compound 3; then compound 2; then compound 1.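

In this assay, chloro in place of hydrogen on an aromatic carbon gives an 18-fold lower number from compound 1 to compound 3 (1.25 log units; beyond the scatter), so a single heavy atom at this place carries a large step toward a stronger inhibitor of growth. Among these compounds, this is the first step that can be read, and it shows that the position between two ring nitrogen atoms, para to a fused ring, is sensitive to substitution in this read-out. Nothing measured here accounts for the size of the step.

The compounds shown leave open whether the step belongs to chloro itself or to any group at this place, which an amine, a methoxy group or a fluoro group there would help to settle. They also leave open whether the same change would act alike on the core of compound 2, as this step rests on a single pair.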